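The compounds below may be only part of what the source reports. "The series", "measured", "known", "first", "only" and "open" are said of these compounds alone.

Measured compounds in a functional assay on HL-60 cells (Homo sapiens) for antiproliferative activity, with a stated time of 24 h; on this read-out higher numbers stand for weaker inhibition and lower numbers for stronger inhibition:
- compound 1 `NC(=O)c1c(NC(=O)c2ccccc2Cl)sc2c1CCN(Cc1ccccc1F)C2` gives 21800 nM
- compound 2 `NC(=O)c1c(NC(=O)c2ccccc2Cl)sc2c1CCN(Cc1ccc(Cl)cc1Cl)C2` gives 8010 nM
- compound 3 `NC(=O)c1c(NC(=O)c2ccccc2Cl)sc2c1CCN(C(=S)Nc1ccccc1I)C2` gives 4430 nM

All three share the same core and differ only in the group on the ring amine nitrogen. The step of a 2.7-fold lower number from compound 1 to compound 2 (0.43 log units; beyond the scatter) and the step of a 4.9-fold lower number from compound 1 to compound 3 (0.69 log units; beyond the scatter) both go beyond the scatter, whereas the step of a 1.8-fold lower number from compound 2 to compound 3 (0.26 log units; within the scatter) does not. Compound 3 therefore sits at the lowest number of the three, separated from compound 1 beyond the scatter but not from compound 2.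

Compound 4 `COc1ccc(NC(=S)N2CCc3c(sc(NC(=O)c4ccccc4Cl)c3C(N)=O)C2)cc1` keeps the thiourea of compound 3 and changes only the aryl group on it: 4-methoxyphenyl in place of 2-iodophenyl on an amide-type nitrogen. Going by the values given here, none of the measured steps bears on this position; the steps from compound 1 to compound 2 and to compound 3 exchange the whole substituent on the ring amine nitrogen, and no pair among compounds 1 to 3 varies the aryl group on the thiourea nitrogen alone. There is thus no measured basis for a directional expectation, and the step of a 1.1-fold higher number from compound 3 to compound 4 (0.05 log units; within the scatter) is expected to stay within the scatter. Compound 4 is estimated at 5000 nM in this assay, with a range from 1500 nM to 16000 nM.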

Compound 4, half-maximal inhibitory concentration: 15700 nM
Estimate against measurement, compound 4: 3.1-fold (0.50 log units) below; the measured number falls inside the stated range.
By their numbers in this assay, from the lowest: compounds 3, 2, 4 and 1 (each within the scatter of the next, the first and the last beyond it).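

In this assay, going by these compounds alone, the aryl group on the thiourea nitrogen matters: 4-methoxyphenyl in place of 2-iodophenyl on this amide-type nitrogen gives a 3.5-fold higher number from compound 3 to compound 4 (0.55 log units; beyond the scatter), the first measured change at this position alone. Keeping the thiourea therefore does not by itself hold the read-out at the level of compound 3, and with 4-methoxyphenyl the thiourea compound is not separated from the two compounds with an aryl group on a saturated chain carbon, as a 2.0-fold higher number from compound 2 to compound 4 (0.29 log units; within the scatter) and a 1.4-fold lower number from compound 1 to compound 4 (0.14 log units; within the scatter) both stay within the scatter. No measurement shown accounts for the step at this position.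

The step exchanges the substituent and its place on the phenyl ring at once, and the compounds shown do not separate these two changes, which 2-methoxyphenyl or 4-iodophenyl on the same nitrogen could do. Also open, as far as these compounds go, are how an unsubstituted phenyl or a cyclohexyl group on this nitrogen would read out, and whether a carbonyl in place of the thiocarbonyl would keep the number of compound 3.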